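A few compounds are considered here, and "the series" means these few. Any claim that something is new, unique, unknown or untested is made for them only; others in the source may bear on it.

Measured compounds in an ADME assay on HeLa cells (Homo sapiens) for cytotoxicity, read by MTT assay, with a stated time of 72 h; a lower number here means that less compound is tolerated, a higher number that more compound is tolerated: compound 1 `Nc1sc2c(c1-c1nc3ccccc3s1)CCCC2` gives 475 ug/mL; compound 2 `Nc1sc2c(c1-c1nc3cc(Cl)ccc3s1)CCC2` gives 75.1 ug/mL; compound 3 `Clc1ccc(/C=N/c2sc3c(c2-c2nc4ccccc4s2)CCCC3)c(Cl)c1` gives 542 ug/mL.

Among these three numbers compound 3 stands highest. Its value sits close to that of compound 1, and the two lie within the usual scatter of this assay, so no order between them can be read. The gap to compound 2 is a different matter: compound 2 lies well beyond the scatter below compound 3, so compound 2 is the least tolerated of the three.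

Compound 4 `Clc1ccccc1/C=N/c1sc2c(c1-c1nc3ccccc3s1)CCCC2` has not yet been measured. It differs from compound 3 by hydrogen in place of chloro on an aromatic carbon. Going by the values given here, no measured pair shows this very change, so the size of the step cannot be taken from the data. Compound 3 and compound 1 show that a large change at this end of the molecule leaves the number within the scatter, and on that basis no step beyond the scatter is expected in this assay. Compound 4 is expected to give 500 ug/mL, with a range from 250 ug/mL to 1000 ug/mL; the expected step is a 1.1-fold lower number from compound 3 to compound 4 (0.04 log units; within the scatter).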

Compound 4, half-maximal cytotoxic concentration: 407 ug/mL
Compound 4: the middle estimate sits 1.2-fold (0.09 log units) above what was measured; the measured number falls inside the stated range.
By their numbers in this assay, from the lowest: compound 2; then compounds 4, 1 and 3 (each within the scatter of the next).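

Going by these compounds alone, this is the first direct reading of a single change on the aromatic ring in this assay: going from 2,4-dichlorophenyl to 2-chlorophenyl, with hydrogen in place of chloro, gives a 1.3-fold lower number from compound 3 to compound 4 (0.12 log units; within the scatter). Within the data shown here, at this position, para to a large group, the chloro therefore has no readable effect on the number, whereas the earlier compounds could only suggest this indirectly. Adding the whole 2-chlorophenyl imine group in place of the free nitrogen end gives a 1.2-fold lower number from compound 1 to compound 4 (0.07 log units; within the scatter), so this larger change also stays within the scatter, and nothing shown explains why these numbers stay together.

Going by these compounds, whether an amine or a carboxylic acid at this position of the aromatic ring would leave the number as undisturbed remains open. On these data alone, compound 2 differs from the others in more than one place, so what sets its number apart also remains open.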